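The source may hold more compounds than are shown below. What is called first, only, known or untested is meant among the compounds shown, and "the series" means these compounds.

Growth inhibition in this series is read in a functional assay on MCF7 cells (Homo sapiens) for inhibition, read by sulforhodamine B assay, with a stated time of 48 h; on this read-out higher numbers stand for weaker inhibition of growth and lower numbers for stronger inhibition of growth. Compound 1 `CCOC(=O)c1nn(-c2ccc(Cl)cc2)c(-c2ccc(Br)cc2)c1CNC(C)(C)C` gives only a limit there, > 511000 nM; > 476000 nM (2 entries), and no number. For the measured compounds named here, compound 2 `CC(C)(C)NCc1c(C(=O)O)nn(-c2ccc(Cl)cc2)c1-c1ccc(F)cc1`, at 270000 nM, holds the only number in this assay and is the sole numeric anchor for the series.

The next compound is compound 3 `CC(C)(C)NCc1c(C(=O)O)nn(-c2ccc(Cl)cc2)c1-c1ccc(Br)cc1`, which keeps the core of compound 2 and differs in one substituent: bromo in place of fluoro on an aromatic carbon. This is bromo in place of fluoro on an aromatic carbon, para to a large group, the 4-fluorophenyl to 4-bromophenyl change.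

Going by the values given here, no measured pair shows what this change does in this assay. The expected size of the step is none beyond the scatter, with no direction favoured. The expectation rests on compound 2 at 270000 nM and on the single-atom nature of the swap. The estimated step of a 1.1-fold lower number from compound 2 to compound 3 (0.03 log units; within the scatter) is therefore small. For compound 3 the expected value is 250000 nM, with an estimated range of 100000 nM to 520000 nM.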

Compound 3, concentration for 50% growth inhibition: 221000 nM
Compound 3: the middle estimate sits 1.1-fold (0.05 log units) above what was measured, within the range that was stated.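

The change from 4-fluorophenyl to 4-bromophenyl, on an aromatic carbon para to a large group, now has a measured pair: this assay gives a 1.2-fold lower number from compound 2 to compound 3 (0.09 log units; within the scatter). At this position, fluoro and bromo therefore do not separate on this read-out, and the series has a second numeric anchor alongside compound 2, although one pair sets no pattern for other substituents or for other parts of the shared core. Nothing in the data at hand bears on why the two halogens read alike, and a single pair inside the scatter offers little to explain.

For the compounds shown here, compound 1 gives only a limit, > 511000 nM; > 476000 nM (2 entries), so no step involving it can be read. On these data alone, it also remains open whether a methoxy, a nitrile or an amine in place of the halogen at this position would give a step beyond the scatter, and whether a number well below those of compound 2 and compound 3 can be reached at all.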